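Sulfonyl aryl swap at the limit of the assay

The source may hold more compounds than are shown below. What is called first, only, known or untested is meant among the compounds shown, and "the series" means these compounds.

Measured in a functional assay on SMMC-7221 cells (Homo sapiens) for antiproliferative activity, read by MTT assay, with a stated time of 48 h; a lower number here means a stronger inhibitor, a higher number a weaker inhibitor:
- compound 1 `CCOc1ccc(-c2nc(NS(=O)(=O)c3ccccc3C(F)(F)F)sc2-c2cc(OC)c(OC)c(OC)c2)cc1`: > 5000 nM (a limit)
- compound 2 `CCOc1ccc(-c2nc(NS(=O)(=O)c3ccc(OC)c(F)c3)sc2-c2cc(OC)c(OC)c(OC)c2)cc1`: > 5000 nM (a limit)

Compound 2 gives only a limit, > 5000 nM, and no number. Among the measured compounds shown here, the series so far shows (the limit of > 5000 nM in this assay, at which 2 of the 2 values shown sit).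

Compound 3 `CCOc1ccc(-c2nc(NS(=O)(=O)c3ccc(C)c(C)c3)sc2-c2cc(OC)c(OC)c(OC)c2)cc1` is next, with 3,4-dimethylphenyl in place of 3-fluoro-4-methoxyphenyl on a sulfonyl sulfur.

For the measured compounds named here, the one measured step, a step that the two limits leave unreadable from compound 1 to compound 2, gives no size to carry over, so no clear direction is expected in this assay. The estimate stays near the limit shared by the measured compounds. The expected change is a step that the limit leaves unreadable from compound 2 to compound 3, and this estimate is loose. Compound 3 is estimated at 7000 nM, with a range of 2000 nM to 25000 nM.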

Compound 3, half-maximal inhibitory concentration: > 5000 nM
Compound 3 was reported as a limit; the forecaster's own chance of this, stated with the estimate: 75%; the middle value lies beyond the limit too.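

In this assay, among the compounds shown here, compound 3 gives > 5000 nM, a limit and not a number, so no step among compound 1, compound 2 and compound 3 can be read. The compounds shown leave open whether these three sulfonyl aryl groups differ at all, as the series stands at one shared value: the limit of > 5000 nM in this assay, at which 3 of the 3 values shown sit.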